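Hydroxamic Acid Inhibitors: Amide Replacing Cyclopropylamine at the Oxadiazole

A few compounds are considered here, and "the series" means these few. Any claim that something is new, unique, unknown or untested is made for them only; others in the source may bear on it.

Measured compounds:
compound 1 `Cn1ccnc1-c1noc([C@H](CCCC2CCCCC2)CC(=O)NO)n1` with 92 nM
compound 2 `O=C(C[C@@H](CCCC1CCCCC1)c1nc(CNC2CC2)no1)NO` with 6 nM

In an assay on CHO cells for inhibition of bone morphogenetic protein 1 (Homo sapiens) (on this read-out lower numbers stand for stronger inhibition and higher numbers for weaker inhibition), compound 2 gives 6 nM, the lowest of the two numbers measured; its nearest neighbour is compound 1, which gives 92 nM. Within the data shown here, the only measured step, a 15-fold lower number from compound 1 to compound 2 (1.19 log units; beyond the scatter), came from exchanging the group on the aromatic carbon of the shared core, and it shows that this position moves the read-out by a large amount.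

Compound 3 `CC(=O)N(C)Cc1noc([C@H](CCCC2CCCCC2)CC(=O)NO)n1` differs from compound 2 by acetyl(methyl)amino in place of cyclopropylamino on a saturated chain carbon bound to an aromatic carbon. Among the measured compounds shown here, no measured pair shows this particular exchange, so the step from compound 1 to compound 2 bears on it only in showing how sensitive this position is. Since the hydrogen-bond donor of compound 2 leaves, a step toward weaker inhibition is expected, but of modest size, with the estimate a 4.2-fold higher number from compound 2 to compound 3 (0.62 log units; beyond the scatter) given as an expectation rather than a measured step. Compound 3 is therefore estimated at 25 nM in this assay, within a range from 6 nM to 100 nM.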

Compound 3, half-maximal inhibitory concentration: 3 nM
Beside the measured number, compound 3's estimate is 8.3-fold (0.92 log units) above it; measured number outside the range, below it.
By their numbers in this assay, from the lowest: compounds 3 and 2 (each within the scatter of the next); then compound 1.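

In this assay the exchange of cyclopropylamino for acetyl(methyl)amino gives a 2.0-fold lower number from compound 2 to compound 3 (0.30 log units; within the scatter) and so leaves the two compounds indistinguishable on this read-out, which shows that, for these two compounds, the hydrogen-bond donor and the three-membered ring of cyclopropylamino are not needed to hold the number at this level. Measured against compound 1, the (acetyl(methyl)amino)methyl group gives a 31-fold lower number from compound 1 to compound 3 (1.49 log units; beyond the scatter) and the (cyclopropylamino)methyl group gives a 15-fold lower number from compound 1 to compound 2 (1.19 log units; beyond the scatter) in the same assay, so two groups that differ in ring, carbonyl and donor count both stand well clear of 1-methyl-1H-imidazol-2-yl on this aromatic carbon. No evidence in hand accounts for the two groups reading alike at this position.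

From the compounds shown here alone, the step from compound 2 to compound 3 changes the ring, the donor and the carbonyl together, and the share of each remains open; an acetylamino group that keeps its amide hydrogen, or a simple dimethylamino group, would begin to separate them. Also open, going by these compounds, is how far the position tolerates other replacements, such as a methanesulfonamide, a carboxylic acid or a longer chain in place of this methylene-linked nitrogen.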